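Chlorinated purine benzyl series: expected effect of a second chloro

The source may hold more compounds than are shown below. What is called first, only, known or untested is meant among the compounds shown, and "the series" means these compounds.

The compounds share a fused bicyclic core carrying a benzyl group that bears a chloromethyl substituent, and they differ in how many chloro groups sit on the core and in where the chloromethyl group sits on the benzyl ring. Compound 1 `ClCc1ccccc1Cn1cnc2c(Cl)nc(Cl)nc21` and compound 3 `ClCc1ccc(Cn2cnc3nc(Cl)nc(Cl)c32)cc1` carry two chloro groups on the core; compound 2 `ClCc1cccc(Cn2cnc3c(Cl)ncnc32)c1` carries one. In a functional assay on MDA-MB-435 cells (Homo sapiens) for cytotoxicity, read by sulforhodamine B assay, with a stated time of 48 h (on this read-out lower numbers stand for stronger inhibition of growth and higher numbers for weaker inhibition of growth), compound 1 gives 3230 nM and compound 3 gives 3010 nM. In this assay compound 2 gives 3310 nM, a number that lies within the usual scatter of the numbers of compound 1 and compound 3, so the three measured compounds cannot be told apart on this read-out.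

Compound 4 `ClCc1cccc(Cn2cnc3c(Cl)nc(Cl)nc32)c1` has not been measured in this assay. It differs from compound 2 by chloro in place of hydrogen on an aromatic carbon. Among the measured compounds shown here, no pair of measured compounds differs in exactly this one place, so no measured step covers the change directly; what the data do show is that compound 1 and compound 3, each with two chloro groups on the core, give numbers within the scatter of compound 2 with one. On that basis the expected step of a 1.1-fold lower number from compound 2 to compound 4 (0.03 log units; within the scatter) is none beyond the scatter. Compound 4 is therefore expected to give 3100 nM, with a range from 1500 nM to 6500 nM.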

Compound 4, concentration for total growth inhibition: 3230 nM
For compound 4 the middle estimate is 1.0-fold (0.02 log units) below the measured one; the measured number falls inside the stated range.
By their numbers in this assay, from the lowest: compounds 3, 1, 4 and 2 (each within the scatter of the next).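

In this assay, chloro in place of hydrogen on the aromatic carbon between two ring nitrogen atoms gives a 1.0-fold lower number from compound 2 to compound 4 (0.01 log units; within the scatter) on a single background, with the chloromethyl group held in one place on the benzyl ring. Among the compounds shown here, this is the first direct reading of the change, since none of the earlier compounds formed a pair differing in this one place. The position therefore takes a chloro group with no step beyond the scatter on this read-out, although this single pair says nothing about other backgrounds in the series, and no accompanying measurement offers an account of the result.

As far as these compounds go, what remains open is whether this flat reading is specific to chloro or extends to other groups on the same carbon, such as an amine, a methoxy group or a longer chain. Also open, from the compounds shown here alone, is whether the chloromethyl group itself matters to the numbers, which a comparison with a plain methyl group or a hydroxymethyl group on the benzyl ring would address.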